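No Readable Step Yet: Changing One Arm of Compound 2

This account rests on a few compounds, and the source may have more. Where it says the series, first, only, none or still open, it means among the compounds named here.

This account follows a single change made to compound 2, `O=C(Nc1sc2c(c1C(=O)NNc1ccc(Cl)cc1)CCCCC2)NS(=O)(=O)c1ccccc1`, and asks what it may do to the compound's power to slow the growth of ovarian cancer cells. In a functional assay on OVCAR-3 cells (Homo sapiens) for inhibition, with a stated time of 48 h (a higher number here means a weaker inhibitor of growth, a lower number a stronger inhibitor of growth), compound 2 gives only a limit of the assay, > 100000 nM, not a number. Compound 1, `CN1CCN(C(=O)c2c(NC(=O)NS(=O)(=O)c3ccccc3)sc3c2CCCCC3)CC1`, shares the same core and differs from compound 2 only in the group carried on one carbonyl carbon. In this assay compound 1 likewise gives only a limit of the assay, > 100000 nM. The step that the two limits leave unreadable from compound 1 to compound 2 cannot be read, because of the limit of > 100000 nM in this assay, at which 2 of the 2 values shown sit.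

Compound 3, `O=C(Nc1sc2c(c1C(=O)N1CCN(c3ccccc3)CC1)CCCCC2)NS(=O)(=O)c1ccccc1`, is the compound not yet measured. Its difference from compound 2 is 4-phenylpiperazin-1-yl in place of ((4-chlorophenyl)amino)amino on a carbonyl carbon. Among the compounds with values here, only the step from compound 1 to compound 2 touches the same carbonyl carbon, and its size is hidden by the two limits, so no measured step gives a direction for the change to compound 3. For compound 3 the step that the limit leaves unreadable from compound 2 to compound 3 is therefore expected to be negligible. Compound 3 is estimated at 150000 nM, within a range from 30000 nM to 600000 nM, most likely reported again as a limit.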

Compound 3, concentration for 50% growth inhibition: 11900 nM
Estimate against measurement, compound 3: 13-fold (1.10 log units) above; measured number below the stated range.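

In this assay, within the data shown here, the group on this carbonyl carbon proves able to bring growth inhibition into a readable range, something the earlier compounds could not show, as the step between them cannot be read; the new change gives an at least 8.4-fold lower number from compound 2 to compound 3 (0.92 log units; beyond the scatter). The group on the piperazine ring counts as well, for putting phenyl in place of methyl on an amine nitrogen in a ring gives an at least 8.4-fold lower number from compound 1 to compound 3 (0.92 log units; beyond the scatter). On these data alone, both steps are minimum sizes, and their full sizes stay unknown because the starting compounds give only a limit of the assay: the limit of > 100000 nM in this assay, at which 2 of the 3 values shown sit.

As far as these compounds go, with a single compound giving a number, it remains open how much of the change depends on the piperazine ring and the phenyl ring acting together, given that compound 2 also carries a six-membered aromatic ring of carbon only and still gives only a limit. Also open, from the compounds shown here alone, is whether a benzyl group or a pyridine ring on that piperazine nitrogen would lower the number further or lose the growth inhibition seen with compound 3.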